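A few compounds are considered here, and "the series" means these few. Any claim that something is new, unique, unknown or untested is made for them only; others in the source may bear on it.

Compound 3 `CN(C)C(=O)CN1CCC(c2cc3c(-c4ccc(=O)n(CCC5CCOCC5)c4)ccnc3[nH]2)CC1` was tested in an ADME assay on cells (Hepatocyte, Rattus norvegicus) for metabolic stability (on this read-out higher numbers stand for fast clearance and lower numbers for slow clearance), where compound 3 gives 14 uL/min. Among the three measured compounds it stands second highest: compound 2 `CN(C)C(=O)CN1CCC(c2cc3c(-c4ccc(=O)n(C5CCOCC5)c4)ccnc3[nH]2)CC1` gives 2.3 uL/min in this assay, the lowest of the set, and compound 1 `COc1cc(F)ccc1-c1ccnc2[nH]c(C3CCN(CC(=O)N(C)C)CC3)cc12` gives 38 uL/min, the highest. Among the measured compounds shown here, the only single change measured is a 6.1-fold higher number from compound 2 to compound 3 (0.78 log units; beyond the scatter), which is beyond the scatter.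

Compound 4 `CCn1cc(-c2ccnc3[nH]c(C4CCN(CC(=O)N(C)C)CC4)cc23)ccc1=O` has not yet been measured. It differs from compound 3 by hydrogen in place of oxan-4-yl on a saturated chain carbon, two bonds along the chain from an aromatic nitrogen. This is not the same kind of change as the measured step: the measured step added a chain while keeping the ring, whereas this one removes the ring from the chain. For the measured compounds named here, there is therefore no direct precedent, and the measured step bears on it only loosely. Because the lower number belongs to compound 2 with 2.3 uL/min, whose group on the aromatic nitrogen is smaller than that of compound 3, a return toward a lower number is expected for compound 4. The estimate for compound 4 is 7 uL/min, with a range from 3 uL/min to 20 uL/min, meaning an expected step of a 2.0-fold lower number from compound 3 to compound 4 (0.30 log units; within the scatter).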

Compound 4, intrinsic clearance in a liver preparation (reported as CLH), per the amount of preparation that the assay uses in the Hepatocyte assay: < 1 uL/min
Compound 4 was reported as a limit (the forecaster's own chance of this, stated with the estimate: 10%); middle value at least 7.0-fold (0.84 log units) away from the limit.
By their numbers in the Hepatocyte assay, from the lowest: compound 2; then compound 3; then compound 1. At a limit, below all of these: compound 4.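

Compound 4's reading in the Hepatocyte assay is a limit of the assay, and the steps read from it are an at least 14-fold lower number from compound 3 to compound 4 (1.14 log units; beyond the scatter), an at least 2.3-fold lower number from compound 2 to compound 4 (0.36 log units; beyond the scatter) and an at least 38-fold lower number from compound 1 to compound 4 (1.57 log units; beyond the scatter), so ethyl on the aromatic nitrogen, with no oxan-4-yl, takes the lowest place among the four compounds. In a physicochemical assay for solubility, in phosphate buffer, at pH 7.4 (a higher number here means a more soluble compound, a lower number a less soluble compound), compound 3 gives 370000 nM, and the step for the same change is an at least 2.7-fold higher number from compound 3 to compound 4 (0.43 log units; beyond the scatter). In the physicochemical assay compound 4 gives > 1000000 nM, which is also a limit of the assay.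

As far as these compounds go, whether a propyl chain or a carboxylic acid on the aromatic nitrogen would stay at the limit of compound 4 in the Hepatocyte assay remains open. The compounds also leave open how far past either limit the true numbers of compound 4 lie.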